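The compounds below may be only part of what the source reports. "The series", "measured", "known", "first", "only" and "open" are said of these compounds alone.

Of the compounds shown here, three sharing one core have been measured so far in a functional assay on A549 cells (Homo sapiens) for antiproliferative activity, read by MTT assay, with a stated time of 48 h; on this read-out lower numbers stand for stronger inhibition and higher numbers for weaker inhibition: compound 1 `COc1ccc2nc(NC(c3cn(-c4ccccc4)nc3-c3ccc(Cl)cc3)c3c(O)ccc4ccccc34)sc2c1` gives 34500 nM on this read-out, compound 2 `COc1ccc2nc(NC(c3cn(-c4ccccc4)nc3-c3ccc([N+](=O)[O-])cc3)c3c(O)ccc4ccccc34)sc2c1` gives 22500 nM and compound 3 `COc1ccc2nc(NC(c3cn(-c4ccccc4)nc3-c3ccccc3)c3c(O)ccc4ccccc34)sc2c1` gives 44600 nM on the same scale. Compound 3 has no separate standing among them, since it lies within the scatter of both others, with a 1.3-fold higher number from compound 1 to compound 3 (0.11 log units; within the scatter) on one side and a 2.0-fold higher number from compound 2 to compound 3 (0.30 log units; within the scatter) on the other.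

Next comes compound 4 `Oc1ccc2ccccc2c1C(Nc1nc2ccc(Cl)cc2s1)c1cn(-c2ccccc2)nc1-c1ccccc1`, which differs from compound 3 at one place: chloro in place of methoxy on an aromatic carbon, so that 6-methoxy-1,3-benzothiazol-2-yl becomes 6-chloro-1,3-benzothiazol-2-yl.

Going by the values given here, no measured step touches this place. The nearest evidence is the exchange of chloro, nitro and hydrogen at another aromatic carbon, where a 1.5-fold lower number from compound 1 to compound 2 (0.19 log units; within the scatter) joins the two steps above, and all three stay within the scatter. These steps bear on the new change only indirectly. No step beyond the scatter is expected in this assay, and the data give no direction. The expected change is a 1.3-fold lower number from compound 3 to compound 4 (0.11 log units; within the scatter) and is no more than a placeholder for that view. Compound 4 is estimated at 35000 nM, with an expected range from 15000 nM to 80000 nM.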

Compound 4, half-maximal inhibitory concentration: 51100 nM
Compound 4: the middle estimate sits 1.5-fold (0.16 log units) below what was measured; the range from low to high includes it.
By their numbers in this assay, from the lowest: compounds 2, 1, 3 and 4 (each within the scatter of the next, the first and the last beyond it).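

In this assay, replacing methoxy with chloro on the aromatic carbon that is meta to a fused ring and para to a fused ring, so that 6-methoxy-1,3-benzothiazol-2-yl becomes 6-chloro-1,3-benzothiazol-2-yl, gives a 1.1-fold higher number from compound 3 to compound 4 (0.06 log units; within the scatter). Going by these compounds alone, this is the first measured step at this position, which compounds 1, 2 and 3 could not address because all three carry methoxy there, and it shows that compound 3 and compound 4 cannot be told apart on this read-out even though the hydrogen-bond acceptor counted for methoxy is absent from chloro. Nothing available accounts for this result or ties it to any property of either group.

With only methoxy and chloro shown here, and only on the compound with an unsubstituted phenyl in the place varied across compounds 1, 2 and 3, it remains open whether the same exchange would stay within the scatter alongside chloro or nitro at that other aromatic carbon. Going by these compounds, it also remains open whether an amine, a carboxylic acid or a longer chain such as butoxy at this position would give a step beyond the scatter.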